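A few compounds are considered here, and "the series" means these few. Any claim that something is new, unique, unknown or untested is made for them only; others in the source may bear on it.

In an ADME assay on CEM-SS cells (Homo sapiens) for cytotoxicity, read by XTT assay, with a stated time of 6 days (a lower number here means that less compound is tolerated, a higher number that more compound is tolerated), compound 1 (`CCCC(=O)OCSc1ccccc1C(=O)NCCC(N)=O`) gives > 100 uM as a limit and not a number. Compound 2 (`NC(=O)CCNC(=O)c1cccc(S)c1`) gives > 100 uM as a limit too. Compound 3 (`CCCC(=O)OCSc1ccccc1C(=O)NCC(N)=O`) gives > 100 uM as a limit as well. Common to the series so far is the limit of > 100 uM in this assay, at which 3 of the 3 values shown sit, and nothing finer. Compound 4 (`CCCC(=O)OCSc1ccccc1C(=O)NCCCCCNC(C)=O`) differs from compound 1 by 3-acetamidopropyl in place of carbamoyl on a saturated chain carbon, two bonds along the chain from an amide-type nitrogen with 3-acetamidopropyl in place of carbamoyl on a saturated chain carbon, two bonds along the chain from an amide-type nitrogen. Among the compounds with values here, the one measured change on this chain, a step that the two limits leave unreadable from compound 1 to compound 3 gives neither size nor direction. The expected a number no higher from compound 1 to compound 4 (the limit leaves the size open) is therefore nothing beyond the scatter in this assay and in neither direction. For compound 4 the estimated value is 100 uM with an expected range of 50 uM to 200 uM in this work.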

Compound 4, half-maximal toxic concentration: 9.2 uM
Estimate against measurement, compound 4: 11-fold (1.04 log units) above; measured number outside the range, below it.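

In this assay this chain position is not silent: 3-acetamidopropyl in place of carbamoyl gives an at least 10-fold lower number from compound 1 to compound 4 (1.03 log units; beyond the scatter), and 4-acetamidobutyl in place of carbamoyl gives an at least 10-fold lower number from compound 3 to compound 4 (1.03 log units; beyond the scatter). Compound 4 is thus the only compound shown with a number and not a limit: the limit of > 100 uM in this assay, at which 3 of the 4 values shown sit. The step between compound 1 and compound 3 cannot be read, and both large steps are bounded by limits, so their full size stays open.

As far as these compounds go, whether the longer chain or its acetamide goes with the lower number remains open. An amine, a carboxylic acid or a plain butyl group in place of 3-acetamidopropyl would separate the two.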